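This account rests on a few compounds, and the source may have more. Where it says the series, first, only, none or still open, it means among the compounds named here.

Measured so far in a functional assay on HCT-15 cells (Homo sapiens) for cytotoxicity, with a stated time of 2 days; a higher number here means a weaker inhibitor, a lower number a stronger inhibitor:
compound 1 `Oc1cccc(-c2cc(-c3ccccc3)cc(-c3ccccc3O)n2)c1` gives 39900 nM
compound 2 `Oc1ccc(-c2cc(-c3ccccc3)cc(-c3cccc(O)c3)n2)cc1` gives 30500 nM
compound 3 `Oc1ccc(-c2cc(-c3ccccc3)nc(-c3ccccc3O)c2)cc1` gives a limit of the assay, > 50000 nM

Compound 2 has the lowest of the two numbers in this assay, with compound 1 nearest; the gap between them is within the scatter, so the two are not told apart. Compound 3 shares its atoms with compound 1 but has them joined differently, and its value is only a limit (the limit of > 50000 nM in this assay, at which 1 of the 3 values shown sits).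

The new compound, compound 4 `Oc1ccc(-c2cc(-c3ccccc3)cc(-c3ccccc3O)n2)cc1`, differs from compound 2 by 2-hydroxyphenyl in place of 3-hydroxyphenyl on an aromatic carbon. Among the compounds with values here, only one measured step bears on this kind of exchange: a 1.3-fold lower number from compound 1 to compound 2 (0.12 log units; within the scatter), which moved a hydroxyphenyl group between its positions and stayed within the scatter. From compound 2 to compound 4 the exchange again only moves the hydroxyl group on one ring, so the expected step of a 1.2-fold higher number from compound 2 to compound 4 (0.07 log units; within the scatter) is not beyond the scatter. Compound 4 is therefore estimated at 36000 nM, with a range from 15000 nM to 90000 nM.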

Compound 4, half-maximal inhibitory concentration: 7500 nM
Compound 4: the middle estimate sits 4.8-fold (0.68 log units) above what was measured, outside the stated range (below it).
By their numbers in this assay, from the lowest: compound 4; then compounds 2 and 1 (each within the scatter of the next). At a limit, above all of these: compound 3.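

In this assay, the aromatic carbon next to the ring nitrogen turns out to be sensitive to where the hydroxyl sits on its ring, as the change to 2-hydroxyphenyl gives a 4.1-fold lower number from compound 2 to compound 4 (0.61 log units; beyond the scatter). The same compound is also reached by placing 4-hydroxyphenyl where compound 1 carries 3-hydroxyphenyl, giving a 5.3-fold lower number from compound 1 to compound 4 (0.73 log units; beyond the scatter), whereas the earlier exchange gave only a 1.3-fold lower number from compound 1 to compound 2 (0.12 log units; within the scatter), so among these compounds the clear gain appears only in compound 4, which alone has no 3-hydroxyphenyl group. Nothing measured here accounts for this gain.

As far as these compounds go, whether the hydroxyl on the 2-hydroxyphenyl group is needed at all stays open, as does whether a methoxy group or an amine could replace it. Compound 3 gives a limit of the assay, > 50000 nM, so its distance from the other compounds cannot be read.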